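The source may report more compounds than this note shows. Statements on the series, on what has been measured and on what is new or still open speak of the compounds shown alone.

Measured so far in a functional assay on HEK293 cells for antagonist activity at Voltage-dependent L-type calcium channel subunit alpha-1D (Rattus norvegicus), read by FLIPR; on this read-out lower numbers stand for stronger inhibition and higher numbers for weaker inhibition:
compound 1, `C=CCOC(=O)C1=C(C)NC(C)=C(C(=O)OC)C1c1ccccc1[N+](=O)[O-]`, gives 10 nM
compound 2, `COC(=O)C1=C(C)NC(C)=C(C(=O)OCCCl)C1c1cccc([N+](=O)[O-])c1`, gives 22 nM
compound 3, `CCCCCOC(=O)C1=C(C)NC(C)=C(C(=O)OCC)C1c1cccc([N+](=O)[O-])c1`, gives 130 nM

Among these three numbers, compound 2 holds the second highest place. Its nearest neighbour is compound 1, whose number is lower by a gap that lies beyond the usual scatter of this assay. Compound 3 stands furthest away, with a number higher than that of compound 2, again by a gap beyond the scatter. Compounds 1 and 3 each differ from compound 2 in more than one place, so none of the three pairs isolates a single structural change.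

Compound 4, `COC(=O)C1=C(C)NC(C)=C(C(=O)OCc2ccc(F)c(F)c2)C1c1cccc([N+](=O)[O-])c1`, is the next compound of interest. It differs from compound 2 by one change: 3,4-difluorophenyl in place of chloromethyl on a saturated chain carbon bound to an oxygen next to a carbonyl group. Among the measured compounds shown here, nothing among the measured compounds speaks directly to this change, so the expectation must rest on the spread of numbers already seen. The three measured numbers sit within a modest range, and a small step toward a higher number, not far beyond the scatter, is expected for compound 4. Compound 4 is therefore expected to give 45 nM, with a likely range from 12 nM to 180 nM. This estimate implies a step of a 2.0-fold higher number from compound 2 to compound 4 (0.31 log units; beyond the scatter), expected rather than measured.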

Compound 4, half-maximal inhibitory concentration: 20 nM
Beside the measured number, compound 4's estimate is 2.3-fold (0.35 log units) above it, within the range that was stated.
By their numbers in this assay, from the lowest: compounds 1, 4 and 2 (each within the scatter of the next, the first and the last beyond it); then compound 3.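

In this assay the step is a 1.1-fold lower number from compound 2 to compound 4 (0.04 log units; within the scatter) when 3,4-difluorophenyl takes the place of chloromethyl on a saturated chain carbon bound to an oxygen next to a carbonyl group, so the two numbers cannot be told apart on this read-out. Among the compounds shown here, this is the first pair in the set that differs in only one place, and it shows that a group of 8 heavy atoms with a six-membered aromatic ring can replace one of 2 heavy atoms with no ring without a measurable loss of inhibition. Nothing among the data shown offers a reason why so large an exchange leaves the number within the scatter.

A single exchange at this position cannot show how far this tolerance reaches: a plain phenyl without fluorine, an amine or a carboxylic acid in the same place could each behave differently. The pair also leaves open whether the same exchange would hold on the core of compound 1 or with the ethyl ester of compound 3 on the other side, since those compounds differ from compound 2 in more than one place.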